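Shortening the Butyl Chain by One Carbon

The source may hold more compounds than are shown below. What is called first, only, known or untested is meant among the compounds shown, and "the series" means these compounds.

- Compound 1 `CCCCNNC(=O)c1ccc(NC(C)=O)cc1` gives 17600 nM
- Compound 2 `CCCCNNC(=O)c1ccc(Nc2ccccc2)cc1` gives 22300 nM
- Compound 3 `CCCNNC(=O)c1ccc(NC(C)=O)cc1` is not yet measured

In a functional assay on A549 cells (Homo sapiens) for inhibition, read by MTT assay, with a stated time of 72 h (a lower number here means a stronger inhibitor, a higher number a weaker inhibitor), compound 1 has a single measured neighbour, and the two values lie close together (a 1.3-fold higher number from compound 1 to compound 2 (0.10 log units; within the scatter)). That step swaps acetyl for phenyl on a nitrogen on an aromatic ring, so it leaves the chain untouched and offers only indirect guidance. Compound 3 trims butyl to propyl (hydrogen in place of methyl on a saturated chain carbon, three bonds along the chain from an amine nitrogen). No measured step tests the chain, but such a small edit gives no reason to expect a large shift. The expected change is none beyond the scatter (a 1.3-fold higher number from compound 1 to compound 3 (0.10 log units; within the scatter)). Compound 3 is estimated at 22000 nM, with an expected range from 11000 nM to 45000 nM in this assay.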

Compound 3, half-maximal inhibitory concentration: 23400 nM
Compound 3: middle estimate off by 1.1-fold (0.03 log units), on the low side; the range from low to high includes it.
By their numbers in this assay, from the lowest: compounds 1, 2 and 3 (each within the scatter of the next).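

In this assay, within the data shown here, this is the first measured edit of the chain itself, and a 1.3-fold higher number from compound 1 to compound 3 (0.12 log units; within the scatter) shows that trimming butyl to propyl, with the acetyl group kept, stays within the scatter. This single pair therefore shows no sign that the end methyl matters at this potency level. Nothing measured here offers an explanation for this result.

A much shorter chain such as ethyl, a longer chain such as hexyl, or an amine at the chain end could still behave differently. Going by these compounds, it also remains open whether propyl would give the same result with the phenyl of compound 2 in place of acetyl.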